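Compound 2 to compound 4: the same chain extension

The source may hold more compounds than are shown below. What is called first, only, known or untested is meant among the compounds shown, and "the series" means these compounds.

In a functional assay on MCF7 cells (Homo sapiens) for antiproliferative activity, read by MTT assay, with a stated time of 72 h (on this read-out higher numbers stand for weaker inhibition and lower numbers for stronger inhibition), compound 1 `CCCCOc1ccc(C2=C(c3ccc(O)cc3)[C@H]3O[C@@H]2C[C@@H]3S(=O)(=O)N(CC)c2ccccc2)cc1` gives 1820 nM and compound 2 `CCCCOc1ccc(C2=C(c3ccc(O)cc3)[C@H]3C[C@H](S(=O)(=O)N(CC)c4ccccc4)[C@@H]2O3)cc1` gives 3290 nM as its value, so the two lie within the scatter of each other. Compound 3 `CCCCCCOc1ccc(C2=C(c3ccc(O)cc3)[C@H]3O[C@@H]2C[C@@H]3S(=O)(=O)N(CC)c2ccccc2)cc1` gives 970 nM as its value, and compound 2 stands above that number beyond the scatter.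

Compound 4 `CCCCCCOc1ccc(C2=C(c3ccc(O)cc3)[C@H]3C[C@H](S(=O)(=O)N(CC)c4ccccc4)[C@@H]2O3)cc1` differs from compound 2 by ethyl in place of hydrogen on a saturated chain carbon, four bonds along the chain from an oxygen on an aromatic ring and this is the same change that separates compound 1 from compound 3. For the measured compounds named here, only one measured step bears on it: a 1.9-fold lower number from compound 1 to compound 3 (0.27 log units; within the scatter) for that change, and this step lies within the scatter. One pair is thin evidence, and the step was measured on compound 1 and not on compound 2. A step of similar size toward a lower number is expected in this assay and it may not clear the scatter. The expected step is a 1.9-fold lower number from compound 2 to compound 4 (0.27 log units; within the scatter) on this reasoning. For compound 4 the estimate is 1750 nM with an expected range from 850 nM to 3400 nM on the same read-out.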

Compound 4, half-maximal inhibitory concentration: 3450 nM
Compound 4: middle estimate off by 2.0-fold (0.29 log units), on the low side; the whole stated range lies below it.
By their numbers in this assay, from the lowest: compounds 3, 1, 2 and 4 (each within the scatter of the next, the first and the last beyond it).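

On the core of compound 2, the change gives a 1.0-fold higher number from compound 2 to compound 4 (0.02 log units; within the scatter) in this assay, so the lean toward a lower number seen on the core of compound 1 does not recur here. The change has now been read on two cores, and on neither does it clear the scatter, so this chain position shows no readable response to ethyl in place of hydrogen. The two steps also cannot be told apart, so no dependence on the core is established: the same change on two cores in this assay, a 1.9-fold lower number (0.27 log units; within the scatter) from compound 1 to compound 3 and a 1.0-fold higher number (0.02 log units; within the scatter) from compound 2 to compound 4, 2.0-fold (0.29 log units) apart, within the scatter of two such steps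

With one pair per core, a small effect of the change cannot be ruled out. On these data alone, whether a longer chain, or an amine or a carboxylic acid on this chain carbon, would move the number beyond the scatter remains open.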